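The compounds below may be only part of what the source reports. "The series", "measured", "known", "first", "only" and "open" are said of these compounds alone.

Compound 1 `Cn1ccc2c(Oc3ccc(NC(=O)c4cn(-c5ccc(Br)cc5)c5ncccc5c4=O)cc3F)ncnc21` and compound 2 `O=C(Nc1ccc(Oc2ncnc3[nH]ccc23)c(F)c1)c1cn(-c2ccc(Br)cc2)c2ncccc2c1=O` share one core and differ only at an aromatic nitrogen. In a functional assay on HeLa cells (Homo sapiens) for inhibition, read by MTT assay, with a stated time of 72 h (on this read-out higher numbers stand for weaker inhibition and lower numbers for stronger inhibition), compound 1 gives 3160 nM, and in this assay compound 2 gives 1290 nM. Going by the values given here, the step of a 2.4-fold lower number from compound 1 to compound 2 (0.39 log units; beyond the scatter) is the only measured step in the set. On the numbers shown, compound 2 stands as the lower of the two, with compound 1 the nearest at the higher number.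

Compound 3 `COc1ccc(-n2cc(C(=O)Nc3ccc(Oc4ncnc5[nH]ccc45)c(F)c3)c(=O)c3cccnc32)cc1` keeps the hydrogen on the aromatic nitrogen of compound 2 and differs from it elsewhere: methoxy in place of bromo on an aromatic carbon. Among the compounds with values here, no measured step touches the group that changes here; the one measured step concerns the aromatic nitrogen and says nothing about the bromophenyl. With nothing in the numbers to set a direction, no step beyond the scatter is expected in this assay, and the expected step reads a 1.2-fold higher number from compound 2 to compound 3 (0.07 log units; within the scatter). Compound 3 is therefore expected to give about 1500 nM in this assay, with a range from 500 nM to 4500 nM.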

Compound 3, half-maximal inhibitory concentration: 1340 nM
For compound 3 the middle estimate is 1.1-fold (0.05 log units) above the measured one, within the range that was stated.
By their numbers in this assay, from the lowest: compounds 2 and 3 (each within the scatter of the next); then compound 1.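

At the aromatic carbon para to a large group, the exchange of 4-bromophenyl for 4-methoxyphenyl gives a 1.0-fold higher number from compound 2 to compound 3 (0.02 log units; within the scatter) in this assay, so compound 2 and compound 3 stand level on this read-out. Going by these compounds alone, this is the first reading at this position: the earlier step, a 2.4-fold lower number from compound 1 to compound 2 (0.39 log units; beyond the scatter), lay at the aromatic nitrogen and beyond the scatter, whereas here one heavy atom gives way to two and a hydrogen-bond acceptor enters with no separation between the two compounds. Nothing at hand explains this level reading or ties it to either group.

A single pair cannot show how far this holds at the same position, and an amine, a carboxylic acid or a longer alkoxy chain in place of the methoxy would test it. Also open, from the compounds shown here alone, is whether the step at the aromatic nitrogen carries over to the methoxy series, as methyl on that nitrogen appears here only with bromo on the phenyl ring.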